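Removing One Chloro from a Dichlorophenyl Piperazine

This account rests on a few compounds, and the source may have more. Where it says the series, first, only, none or still open, it means among the compounds named here.

Compound 1, `CC1CC(=O)N(CC(=O)N2CCN(c3ccc(Cl)c(Cl)c3)CC2)C1=O`: 54.1 mg/kg
Compound 2, `CC1CC(=O)N(CC(=O)N2CCN(c3cccc(Cl)c3)CC2)C1=O`: 40.3 mg/kg
Compound 3, `CCC1(C)CC(=O)N(CC(=O)N2CCN(c3ccc(F)cc3)CC2)C1=O`: 130 mg/kg

These numbers come from a functional assay on the whole organism (strain CD1) with Mus musculus as the target (a lower number here means that less compound is needed, a higher number that more compound is needed for the effect), a measure of how much compound is needed in a living animal. Among the three measured compounds, compound 1 stands second highest; compound 2 is the nearest neighbour, with a gap within the usual scatter, while compound 3 lies furthest away and is the only one separated from compound 1 by more than the scatter.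

Compound 4, `CC1CC(=O)N(CC(=O)N2CCN(c3ccc(Cl)cc3)CC2)C1=O`, has not yet been measured. It differs from compound 1 in one place: hydrogen in place of chloro on an aromatic carbon. Within the data shown here, the only measured step of the same kind is a 1.3-fold lower number from compound 1 to compound 2 (0.13 log units; within the scatter), which removes the other chloro of compound 1 and stays within the scatter. Compound 3 differs from compound 1 both in the halogen and in the core, so its value speaks only loosely to this change.

On this basis no step beyond the scatter is expected, and compound 4 is estimated at 55 mg/kg, with a likely range from 25 mg/kg to 120 mg/kg. In other words, the expected change is a 1.0-fold higher number from compound 1 to compound 4 (0.01 log units; within the scatter).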

Compound 4, dose for half-maximal effect: > 250 mg/kg
Compound 4: a limit, no number; the forecaster's own chance of this, stated with the estimate: 5%; at least 4.5-fold (0.65 log units) between middle value and limit.
By their numbers in this assay, from the lowest: compounds 2 and 1 (each within the scatter of the next); then compound 3. At a limit, above all of these: compound 4.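

In this assay, compound 4 gives a limit of the assay and not a number: the limit of > 250 mg/kg in this assay, at which 1 of the 4 values shown sits.

Taking a chloro off the 3,4-dichlorophenyl group therefore has no single outcome: the change to 4-chlorophenyl gives an at least 4.6-fold higher number from compound 1 to compound 4 (0.66 log units; beyond the scatter), while removing the other chloro gave a 1.3-fold lower number from compound 1 to compound 2 (0.13 log units; within the scatter). The comparison of the two single-chloro compounds points the same way, since 4-chlorophenyl in place of 3-chlorophenyl gives an at least 6.2-fold higher number from compound 2 to compound 4 (0.79 log units; beyond the scatter), so among these three compounds the chloro that leaves in going to compound 4 is the one whose presence goes with the lower numbers, and compounds 1 and 2 both keep it.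

From the compounds shown here alone, how far the true number of compound 4 lies past its limit remains open, so the full size of both new steps is unknown. Also open, going by these compounds, is whether this place needs a chloro as such, or whether a methyl, a methoxy or a trifluoromethyl group there, on a phenyl that otherwise carries no substituent, would keep the number near that of compound 2.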